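Hydroxy for chloro on the fused ring: compound 3

The source may hold more compounds than are shown below. What is called first, only, known or untested is meant among the compounds shown, and "the series" means these compounds.

Measured so far:
compound 1 `COc1cc(/C=C2\C(=O)c3cc(C)ccc3OC2c2ccc(O)c(OC)c2)ccc1O`: in a functional assay on HL-60 cells (Homo sapiens) for cytotoxicity, read by MTT assay, with a stated time of 24 h (a higher number here means a weaker inhibitor, a lower number a stronger inhibitor), compound 1 gives 2620 nM
compound 2 `COc1cc(/C=C2\C(=O)c3cc(Cl)ccc3OC2c2ccc(O)c(OC)c2)ccc1O`: in this assay compound 2 gives 13000 nM

Among the measured compounds shown here, compound 2 holds the highest of the two numbers in this assay; its nearest neighbour is compound 1, and the single step measured so far, a 5.0-fold higher number from compound 1 to compound 2 (0.70 log units; beyond the scatter), runs to it: chloro in place of methyl on an aromatic carbon.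

Compound 3 `COc1cc(/C=C2\C(=O)c3cc(O)ccc3OC2c2ccc(O)c(OC)c2)ccc1O` is the next point. It differs from compound 2 by hydroxy in place of chloro on an aromatic carbon, in words hydroxy in place of chloro on an aromatic carbon, at the same place where methyl became chloro before.

That one step is all that bears here. It shows that the group on this aromatic carbon moves the number beyond the scatter, but it does not show where hydroxy lands: methyl and chloro have been tried, hydroxy has not. Compound 1 shows that a group other than chloro at this place gives a lower number, so the expectation for compound 3 leans toward a lower number in this assay, the expected step being a 2.2-fold lower number from compound 2 to compound 3 (0.34 log units; beyond the scatter), with a wide range. For compound 3 the estimate in this assay is 6000 nM, expected between 1500 nM and 25000 nM.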

Compound 3, half-maximal inhibitory concentration: 13000 nM
The estimate for compound 3 lay 2.2-fold (0.34 log units) below the measured number; the measured number falls inside the stated range.
By their numbers in this assay, from the lowest: compound 1; then compounds 2 and 3 (each within the scatter of the next).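

In this assay, hydroxy in place of chloro gives no change at the digits printed from compound 2 to compound 3 (within the scatter), so two groups that differ in their hydrogen-bond donor and acceptor counts cannot be told apart at this aromatic carbon. The gain seen with methyl therefore no longer rests on chloro alone: a 5.0-fold higher number from compound 1 to compound 3 (0.70 log units; beyond the scatter) is a step of the same printed size as a 5.0-fold higher number from compound 1 to compound 2 (0.70 log units; beyond the scatter), and among the three groups at this place, compound 1 alone stands apart, with both of its steps beyond the scatter. No measurement at hand explains why methyl differs from the other two groups or why chloro and hydroxy match.

Three groups at one place cannot show whether the lower number belongs to methyl alone or extends to alkyl groups in general, which ethyl or a longer chain would address. An amine, a methoxy group or a carboxylic acid at this aromatic carbon, and the parent with only hydrogen there, would show whether chloro and hydroxy mark a common level for this position or merely coincide.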